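Compound 1 to Compound 4: One Aryl Group Exchanged

The compounds below may be only part of what the source reports. "The series", "measured", "known", "first", "only" and "open" are said of these compounds alone.

Measured in a functional assay on NCI-H1975 cells (Homo sapiens) for cytotoxicity, read by MTT assay, with a stated time of 72 h; a higher number here means a weaker inhibitor, a lower number a stronger inhibitor:
- compound 1 `O=C(N/N=C/c1ccc(Br)cc1)N1CCc2ncnc(Nc3ccc(F)c(Cl)c3)c2C1`: > 200000 nM (a limit, not a number)
- compound 2 `O=C(N/N=C/c1cccc([N+](=O)[O-])c1)N1CCc2ncnc(Nc3ccc(F)c(Cl)c3)c2C1`: 86900 nM
- compound 3 `O=C(N/N=C/c1cc(F)c(F)cc1Cl)N1CCc2ncnc(Nc3ccc(F)c(Cl)c3)c2C1`: 46100 nM

In this assay compound 1 gives > 200000 nM, which is only a limit. Its exact place on the scale is therefore unknown.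

Compound 4 `O=C(N/N=C/c1ccc(Br)cc1)N1CCc2ncnc(Nc3cccc(Br)c3)c2C1` keeps the 4-bromophenyl of compound 1 and changes another part of the molecule: 3-bromophenyl in place of 3-chloro-4-fluorophenyl on a nitrogen on an aromatic ring. In words, it has 3-bromophenyl in place of 3-chloro-4-fluorophenyl on a nitrogen on an aromatic ring.

The measured steps bear on this only indirectly. The changes on the carbon with a double bond to nitrogen gave an at least 2.3-fold lower number from compound 1 to compound 2 (0.36 log units; beyond the scatter) and an at least 4.3-fold lower number from compound 1 to compound 3 (0.63 log units; beyond the scatter), while a 1.9-fold lower number from compound 2 to compound 3 (0.28 log units; within the scatter) stays within the scatter. Among the measured compounds shown here, no measured step changes the group on the nitrogen, so the data give no firm direction for this swap.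

The step expected is an at least 1.3-fold lower number from compound 1 to compound 4 (0.12 log units; that floor lies within the scatter), and it is not expected to go beyond the scatter. For compound 4 the estimated value is 150000 nM, with an expected range from 60000 nM to 300000 nM.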

Compound 4, half-maximal inhibitory concentration: 51000 nM
Estimate against measurement, compound 4: 2.9-fold (0.47 log units) above; measured number below the stated range.
By their numbers in this assay, from the lowest: compounds 3, 4 and 2 (each within the scatter of the next). At a limit, above all of these: compound 1.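

Exchanging 3-chloro-4-fluorophenyl for 3-bromophenyl on the nitrogen gives an at least 3.9-fold lower number from compound 1 to compound 4 (0.59 log units; beyond the scatter) in this assay, so the read-out responds to the group at this place as well as to the aryl group on the carbon with a double bond to nitrogen. Compound 4 keeps the 4-bromophenyl of compound 1, yet it gives a measured number, so this single exchange is enough to bring the compound off the limit. The full size of the step stays unknown because its starting point is only a limit: the limit of > 200000 nM in this assay, at which 1 of the 4 values shown sits.

The compounds shown leave open whether the same exchange would lower the number with the 3-nitrophenyl of compound 2 or the 2-chloro-4,5-difluorophenyl of compound 3 in place of the 4-bromophenyl. They also leave open how an unsubstituted phenyl, or a phenyl carrying a methoxy group or an amine, would behave on this nitrogen.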